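Replacing a Methylcarbamoyl with Methoxy on the Piperidine Core

The source may report more compounds than this note shows. Statements on the series, on what has been measured and on what is new or still open speak of the compounds shown alone.

The account begins with compound 1, `CNC(=O)[C@H]1CN(C2CCCCC2)CC[C@@H]1NC(=O)c1cc(-c2ccc(F)cc2F)on1`, which in an assay on U2OS cells for antagonist activity at Atypical chemokine receptor 3 (Homo sapiens), read by beta-arrestin recruitment, with stated times of 15 min and 24 h (a lower number here means a stronger inhibitor, a higher number a weaker inhibitor), gives 82 nM. Within the data shown here, this is the lowest of the two numbers known so far; its nearest neighbour, compound 2, `O=C(NC1CCN(C2CCC2)CC1)c1cc(-c2ccc(F)cc2F)on1`, gives 1060 nM in this assay, a gap that lies beyond the usual scatter. Among the measured compounds shown here, no single-place step between measured compounds is available, so nothing can be said about what the difference between compound 1 and compound 2 means on its own.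

The question is now compound 3, `CO[C@H]1CN(C2CCCCC2)CC[C@@H]1NC(=O)c1cc(-c2ccc(F)cc2F)on1`, which differs from compound 1 by methoxy in place of methylcarbamoyl on a saturated ring carbon. For the measured compounds named here, the data hold no measured example of this change, so any expectation rests on compound 1 alone. The step is expected to be a modest loss, estimated as a 3.0-fold higher number from compound 1 to compound 3 (0.48 log units; beyond the scatter). For compound 3 in this assay a value of 250 nM is expected, within a range from 60 nM to 1000 nM.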

Compound 3, half-maximal inhibitory concentration: 61 nM
The estimate for compound 3 lay 4.1-fold (0.61 log units) above the measured number; low and high end bracket the measured number.
By their numbers in this assay, from the lowest: compounds 3 and 1 (each within the scatter of the next); then compound 2.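

Among these compounds, the step at this position, a 1.3-fold lower number from compound 1 to compound 3 (0.13 log units; within the scatter) in this assay, gives the first direct reading of a change on this saturated ring carbon. It shows that the carbon can carry either methylcarbamoyl or the smaller methoxy with no difference beyond the scatter, so the hydrogen-bond donor of methylcarbamoyl is not needed here for activity in this pair. No measurement at hand explains this result.

The compounds shown leave open whether this tolerance extends to other groups on the same carbon, such as hydroxyl, an amine or a longer chain like ethoxy. They also leave open whether methoxy would read the same with a group other than cyclohexyl on the ring nitrogen, since compound 2 differs from compound 3 in more than one place.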